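The source may report more compounds than this note shows. Statements on the series, on what has been measured and on what is new or still open speak of the compounds shown alone.

Compound 2 `O=c1c2ccccc2nc(-c2ccccc2)n1/N=C/c1ccc(Oc2ccccc2)cc1` is the second highest of three numbers in a physicochemical assay for lipophilicity, in phosphate buffer, measured as octanol-water partition (a lower number here means a more polar compound, a higher number a more lipophilic compound), where compound 2 gives 6.13. Compound 1 `CCCc1nc2ccccc2c(=O)n1/N=C/c1ccc(Oc2ccc(Cl)cc2)cc1` gives 5.78 in this assay, and compound 3 `Cc1cc(Oc2ccc(/C=N/n3c(-c4ccccc4)nc4ccccc4c3=O)cc2)ccc1Cl` gives 6.52. Compound 4 `CCCc1nc2ccccc2c(=O)n1/N=C/c1ccc(Oc2ccccc2)cc1` has not yet been measured; it differs from compound 2 by propyl in place of phenyl on an aromatic carbon. For the measured compounds named here, no measured step swaps a phenyl for a propyl; the only step recorded, a number 0.39 log units higher from compound 2 to compound 3 (beyond the scatter), changes a different part of the molecule and gives no guidance here. Compound 1, which also carries a propyl at that place, stands lower than compound 2. A downward step a number 0.93 log units lower from compound 2 to compound 4 (beyond the scatter) is therefore expected for compound 4. The estimate for compound 4 is 5.2, within a range of 4.7 to 5.7.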

Compound 4, partition coefficient: 5.2
Estimate against measurement, compound 4: no gap at the digits printed, within the range that was stated.
By their numbers in this assay, from the lowest: compound 4; then compound 1; then compound 2; then compound 3.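

In this assay, the aromatic carbon between two ring nitrogen atoms now has a direct reading: propyl in place of phenyl gives a number 0.93 log units lower from compound 2 to compound 4 (beyond the scatter). A second single change, hydrogen in place of chloro, gives a number 0.58 log units lower from compound 1 to compound 4 (beyond the scatter), so each of these two places alone moves the number beyond the scatter. No measurement here gives a reason for either step. Where an amine or a longer chain at the first place would fall remains open. So does whether the chloro step would keep its size with phenyl in place of propyl.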